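The compounds below may be only part of what the source reports. "The series", "measured", "known", "first", "only" and "open" are said of these compounds alone.

Measured in an assay on HEK293 cells for displacement of a labelled ligand from Neuronal acetylcholine receptor; alpha3/beta4 (Homo sapiens), read by scintillation counting, with a stated time of 120 min; a lower number here means a stronger inhibitor, a higher number a weaker inhibitor:
compound 1 `Fc1ccc(COc2cccc(-c3cn(C4CN5CCC4CC5)nn3)c2)cc1` gives 13.9 nM
compound 2 `FCCCOc1cccc(-c2cn([C@H]3CN4CCC3CC4)nn2)c1` gives 1630 nM
compound 3 `FCCCOc1cccc(-c2cn([C@@H]3CN4CCC3CC4)nn2)c1` gives 19.5 nM

Compound 3 stands second highest of the three numbers. Its nearest neighbour is compound 1, within the scatter, so no order between these two is claimed. Going by the values given here, the furthest is compound 2, and the one measured step here, an 84-fold lower number from compound 2 to compound 3 (1.92 log units; beyond the scatter), is large: the stereocentre drawn R in compound 2 and S in compound 3 separates a weak binder from a strong one.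

Compound 4 `FCCCOc1cccc(-c2cn(C3CN4CCC3CC4)nn2)c1` differs from compound 3 only in this way: the two compounds have the same atoms and bonds; at least one stereo element is drawn with a configuration in one of them and without one in the other: 1 of 3 stereo elements differ; a stereocentre at a saturated ring carbon is drawn S in compound 3 and without a configuration in compound 4. Drawn without a configuration, compound 4 carries both arrangements, and the step from compound 2 to compound 3 is therefore the one that bears on it. A small rise in number is expected, a 2.1-fold higher number from compound 3 to compound 4 (0.31 log units; beyond the scatter), since the number of compound 2 in this assay is so much higher than that of compound 3. For compound 4 a value of 40 nM is estimated, between 18 nM and 90 nM.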

Compound 4, inhibition constant: 44.4 nM
Compound 4: the middle estimate sits 1.1-fold (0.05 log units) below what was measured; measured number inside the range.
By their numbers in this assay, from the lowest: compounds 1 and 3 (each within the scatter of the next); then compound 4; then compound 2.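

In this assay, the drawing without a configuration lies far closer to the S form than to the R form: the step to the S form is modest (a 2.3-fold higher number from compound 3 to compound 4 (0.36 log units; beyond the scatter)), the step from the R form large (a 37-fold lower number from compound 2 to compound 4 (1.56 log units; beyond the scatter)). With the stereocentre undefined in both compounds, 2-fluoroethyl in place of 4-fluorophenyl is also a modest step (a 3.2-fold higher number from compound 1 to compound 4 (0.50 log units; beyond the scatter)). The reading at this position rests on a single kind of contrast: the fact that one of compounds 3 and 4 is drawn with a defined configuration and the other without, at the place where they differ

Going by these compounds, whether the S form keeps its edge over the R form with 4-fluorophenyl in place stays open, as compound 1 stands only without a configuration. Also open, on these data alone, is how a longer chain, or an amine in place of the chain's fluorine, would fare on the S form.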